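Removing the Nitrile from the Analogue with the Highest Number

The source may report more compounds than this note shows. Statements on the series, on what has been measured and on what is new or still open speak of the compounds shown alone.

Compound 1 `COCc1cc(C(C)=O)c(O)cc1OCCCCCCC#N` gives 47% in an assay on isolated protein for inhibition of leukotriene B4 receptor 1 (Homo sapiens), tested at 10 uM; on this read-out lower numbers stand for less inhibition and higher numbers for more inhibition at the one concentration tested (going by the name of the read-out).
Compound 2 `CC(=O)c1cc(CO)c(OCCCCCCC#N)cc1O` gives 40% in this assay.
Compound 3 `C=CCc1cc(C(C)=O)c(O)cc1OCCCCCCC#N` gives 97% in this assay.

Compound 3 stands highest of the three, with a number 50 percentage points higher from compound 1 to compound 3 (beyond the scatter) and a number 57 percentage points higher from compound 2 to compound 3 (beyond the scatter). The step to compound 4 `C=CCc1cc(C(C)=O)c(O)cc1OCCCCC` is a different kind of change: hydrogen in place of cyanomethyl on a saturated chain carbon, five bonds along the chain from an oxygen on an aromatic ring. Among the compounds with values here, no measured step touches this part of the chain; the two large steps concern only the group on the aromatic ring, so they give no direct guide. Since compound 3 is already near the top of the scale, compound 4 is expected to come out somewhat lower, with a number 27 percentage points lower from compound 3 to compound 4 (beyond the scatter) as the estimated step, though with wide uncertainty. The estimate for compound 4 is 70%, ranging from 35% to 95%.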

Compound 4, a percentage reported as inhibition, at one concentration (the size of the read-out at that concentration, not a potency): 60%
Compound 4: the middle estimate sits 10 percentage points above what was measured; measured number inside the range.
By their numbers in this assay, from the lowest: compounds 2 and 1 (each within the scatter of the next); then compound 4; then compound 3.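

The earlier steps shown here changed only the group on the aromatic ring, whereas this one changes the far end of the chain. In this assay, replacing cyanomethyl with hydrogen gives a number 37 percentage points lower from compound 3 to compound 4 (beyond the scatter), so the end of the chain also affects the read-out, even with the allyl-bearing core held constant. Nothing shown explains why the number falls.

As far as these compounds go, this change removes the nitrile and shortens the chain together, so their separate contributions remain unknown. A longer chain without a nitrile, or a carboxylic acid or an amine at the chain end, could help separate them.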